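The compounds below may be only part of what the source reports. "The series", "measured", "known", "first", "only" and "open" are said of these compounds alone.

The series shares one core, seen in compound 1 `CS(=O)(=O)CCNc1nc(-c2ccc3ncnc(Nc4ccc(OCc5cccc(F)c5)c(Cl)c4)c3c2)cs1` and compound 2 `CS(=O)(=O)CCNc1nc(-c2ccc3ncnc(Nc4ccc(OCc5ccccc5)cc4)c3c2)cs1`. In a functional assay on HFF cells (Homo sapiens) for inhibition (a higher number here means a weaker inhibitor, a lower number a stronger inhibitor), compound 2 gives > 30000 nM, which is a limit of the assay and not a number. Compound 1 likewise returns > 30000 nM in this assay, again a limit. For the measured compounds named here, compound 2 therefore stands at the assay limit with nothing numeric to place it against, and the one further value sits at the same limit, as the limit of > 30000 nM in this assay, at which 2 of the 2 values shown sit, sums up. Compound 3 `CS(=O)(=O)CCNc1nc(-c2ccc3ncnc(Nc4ccc(OCc5ccccc5)c(Cl)c4)c3c2)cs1` is the next member to be measured. It differs from compound 2 by chloro in place of hydrogen on an aromatic carbon. Going by the values given here, no step between measured compounds is available to size this change, and with both measured values at the limit no direction can be read; the expectation is for no step beyond the scatter. Compound 3 is accordingly expected near 50000 nM, within a range of 20000 nM to 200000 nM, most likely reported as a limit once more. The estimated step is a step that the limit leaves unreadable from compound 2 to compound 3.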

Compound 3, half-maximal inhibitory concentration: > 30000 nM
Compound 3 was reported as a limit; the forecaster's own chance of this, stated with the estimate: 85%; the middle value lies beyond the limit too.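

In this assay, for the compounds shown here, compound 3 gives > 30000 nM, again a limit and not a number, so no step from compound 3 to compound 1 or compound 2 can be read. What chloro or fluoro in place of hydrogen does to inhibition stays open, because all values share one limit: the limit of > 30000 nM in this assay, at which 3 of the 3 values shown sit.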